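Replacing an amino ester side chain with an ether in a triazolopyrimidine

A few compounds are considered here, and "the series" means these few. Any claim that something is new, unique, unknown or untested is made for them only; others in the source may bear on it.

Of the compounds shown here, three sharing one fused core have been measured in an in vitro assay on 293-EBNA cells for binding affinity to corticotropin-releasing factor receptor 1 (Homo sapiens); on this read-out higher numbers stand for weaker inhibition and lower numbers for stronger inhibition. Compound 1 `Cc1nc(N2CCCC2)c2nnn(-c3ccc(C(C)C)cc3Br)c2n1` gives 194 nM, compound 2 `CCCCN(CC)c1nc(C)nc2c1nnn2-c1ccc(C(C)C)cc1Br` gives 7.5 nM, and compound 3 `CCC(Nc1nc(C)nc2c1nnn2-c1ccc(C(C)C)cc1Br)C(=O)OC` gives 19.4 nM, which places compound 3 second highest of the three numbers shown. The steps among them are a 26-fold lower number from compound 1 to compound 2 (1.41 log units; beyond the scatter), a 10-fold lower number from compound 1 to compound 3 (1.00 log units; beyond the scatter) and a 2.6-fold higher number from compound 2 to compound 3 (0.41 log units; beyond the scatter), so opening the ring on the substituted side chain helped markedly, and the ester-bearing chain of compound 3 sits somewhat behind the plain dialkylamino chain of compound 2.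

Compound 4 `CCC(COC)Oc1nc(C)nc2c1nnn2-c1ccc(C(C)C)cc1Br` changes compound 3 by a group of 7 heavy atoms (5 carbon, 2 oxygen; no ring) in place of a group of 8 heavy atoms (5 carbon, 1 nitrogen, 2 oxygen; no ring), on an aromatic carbon. Within the data shown here, no measured step swaps a nitrogen-linked chain for an oxygen-linked one, so the bearing of the earlier steps is indirect; the closest guide is a 2.6-fold higher number from compound 2 to compound 3 (0.41 log units; beyond the scatter), which shows that altering this chain moves the number by a modest step rather than by one as large as a 26-fold lower number from compound 1 to compound 2 (1.41 log units; beyond the scatter). On that basis compound 4 is expected to land somewhat weaker than compound 3, a step of about a 2.3-fold higher number from compound 3 to compound 4 (0.37 log units; beyond the scatter), with an estimated value of 45 nM and a plausible range from 10 nM to 200 nM.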

Compound 4, inhibition constant: 1.9 nM
Beside the measured number, compound 4's estimate is 24-fold (1.37 log units) above it; the measured number lies below the stated range.
By their numbers in this assay, from the lowest: compound 4; then compound 2; then compound 3; then compound 1.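

In this assay the step of a 10-fold lower number from compound 3 to compound 4 (1.01 log units; beyond the scatter) shows that this position does not need a nitrogen-linked chain: 1-(methoxymethyl)propoxy, with 0 hydrogen-bond donors, gives the lowest number of the four compounds. It also stands ahead of the two other nitrogen-linked groups, with a 3.9-fold lower number from compound 2 to compound 4 (0.60 log units; beyond the scatter) and a 100-fold lower number from compound 1 to compound 4 (2.01 log units; beyond the scatter) showing that the chain on this aromatic carbon can still move the number a long way. Nothing measured here explains the gain.

From the compounds shown here alone, in the step from compound 3 to compound 4, the linking atom and the end of the chain change together, so their shares remain unknown; the amine carrying the same 1-(methoxymethyl)propyl chain would separate them. Going by these compounds, whether a longer ether chain or a carboxylic acid at the chain end would hold this number also remains open.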